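Hexafluoroisopropoxy in place of sec-butoxy on a nitrile-bearing ring

A few compounds are considered here, and "the series" means these few. Any claim that something is new, unique, unknown or untested is made for them only; others in the source may bear on it.

Three oxadiazole-linked propanoic acids have been measured in a functional assay on CHO cells for agonist activity at sphingosine 1-phosphate receptor 5 (Homo sapiens), read by GTPgammaS binding; on this read-out higher numbers stand for an effect only at larger amounts of compound and lower numbers for an effect already at smaller amounts. For the measured compounds named here, compound 1 `Cc1cc(-c2nc(-c3ccc(CCC(=O)O)cc3C)no2)ccc1OC(C)C` gives 210 nM, and compound 2 `COc1cc(-c2nc(-c3ccc(CCC(=O)O)cc3C)no2)ccc1OC(C)C` gives 270 nM; the step of a 1.3-fold higher number from compound 1 to compound 2 (0.11 log units; within the scatter) is the only single-place comparison among the measured compounds. Compound 3 `CC[C@H](C)Oc1ccc(-c2nc(-c3ccc(CCC(=O)O)cc3C)no2)cc1C#N` gives 15 nM and so stands at the lowest number of the three, well apart from both compound 1 and compound 2, though it differs from each of them in more than one place, so no single step accounts for that gap.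

Compound 4 `Cc1cc(CCC(=O)O)ccc1-c1noc(-c2ccc(OC(C(F)(F)F)C(F)(F)F)c(C#N)c2)n1` is obtained from compound 3 by the change (2,2,2-trifluoro-1-(trifluoromethyl)ethyl in place of sec-butyl on an oxygen on an aromatic ring). Going by the values given here, none of the measured steps touches the group on this oxygen, and the one measured step concerns a different position and lies within the scatter, so there is no direct guide to the size or direction of this change. The step is therefore expected to be modest and uncertain, estimated as a 2.0-fold higher number from compound 3 to compound 4 (0.30 log units; within the scatter). Compound 4 is estimated at 30 nM, within a range from 8 nM to 120 nM.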

Compound 4, half-maximal effective concentration: 0.7 nM
Beside the measured number, compound 4's estimate is 43-fold (1.63 log units) above it, and the stated range ends above it.
By their numbers in this assay, from the lowest: compound 4; then compound 3; then compounds 1 and 2 (each within the scatter of the next).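

In this assay, the group on the oxygen on an aromatic ring proves to be a strong lever: 2,2,2-trifluoro-1-(trifluoromethyl)ethyl in place of sec-butyl gives a 21-fold lower number from compound 3 to compound 4 (1.33 log units; beyond the scatter). For the compounds shown here, the only earlier single-place step, a 1.3-fold higher number from compound 1 to compound 2 (0.11 log units; within the scatter), concerned a different place and showed no such shift, so this is the first sign that a single change can move the number this far. Nothing available here bears on why the number falls.

The change swaps carbon for fluorine, adds heavy atoms and removes the one defined stereocentre of sec-butyl, and this single pair cannot separate these differences. Going by these compounds, whether 2,2,2-trifluoroethyl or tert-butyl on the same oxygen would give a similar step remains open, as does whether the step would hold on a ring carrying methyl or methoxy instead of nitrile.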